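From butylsulfonyl to benzylcarbamoyl on an amine nitrogen

A few compounds are considered here, and "the series" means these few. Any claim that something is new, unique, unknown or untested is made for them only; others in the source may bear on it.

Within the data shown here, in a functional assay for inhibition, with Homo sapiens as the target (on this read-out lower numbers stand for stronger inhibition and higher numbers for weaker inhibition), compound 2 `CCCCS(=O)(=O)N[C@@H](CNC(=O)c1cc2cc(CCC3CCNCC3)sc2s1)C(=O)O` reads 32 nM and holds the higher of the two numbers so far. Among the measured compounds shown here, its only measured neighbour, compound 1 `O=C(NC[C@H](NS(=O)(=O)c1ccccc1)C(=O)O)c1cc2cc(CCC3CCNCC3)sc2s1`, reads 8 nM on the same core. Compound 3 `O=C(NCc1ccccc1)N[C@@H](CNC(=O)c1cc2cc(CCC3CCNCC3)sc2s1)C(=O)O` keeps that core but has not yet been measured. It carries benzylcarbamoyl in place of butylsulfonyl on an amine nitrogen.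

For the measured compounds named here, one measured step bears on this change. The step of a 4.0-fold higher number from compound 1 to compound 2 (0.60 log units; beyond the scatter) came with butyl in place of phenyl on a sulfonyl sulfur, and it is modest but beyond the scatter. It is only a partial guide. Going by the values given here, compound 3 regains a six-membered aromatic ring, as does compound 1 at 8 nM but it has no sulfonyl group, and no measured compound carries benzylcarbamoyl. The expected change in this assay is therefore small, leaning towards a lower number and not clearly beyond the scatter: a 1.3-fold lower number from compound 2 to compound 3 (0.11 log units; within the scatter) is the step estimated here. Compound 3 is estimated at 25 nM with an expected range of 8 nM to 80 nM until it is measured.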

Compound 3, half-maximal inhibitory concentration: 76 nM
Compound 3: the middle estimate sits 3.0-fold (0.48 log units) below what was measured, and the stated range covers the measured number.
By their numbers in this assay, from the lowest: compound 1; then compound 2; then compound 3.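

In this assay, the result shows that a six-membered aromatic ring on this amine nitrogen does not by itself bring back a low number: benzylcarbamoyl carries such a ring, yet replacing butylsulfonyl with it gives a 2.4-fold higher number from compound 2 to compound 3 (0.38 log units; beyond the scatter). Among these compounds, replacing phenylsulfonyl with benzylcarbamoyl gives a larger step, a 9.5-fold higher number from compound 1 to compound 3 (0.98 log units; beyond the scatter), so both sulfonyl compounds, with or without a ring, read lower than the single carbamoyl compound, and none of the three goes against this. No measurement shown here explains why the number rises with benzylcarbamoyl.

The change from phenylsulfonyl to benzylcarbamoyl alters both the linking group and the way the ring is attached, so these compounds cannot separate the two effects; phenylcarbamoyl and benzylsulfonyl on the same nitrogen would pull them apart. A butylcarbamoyl group would complete the comparison with compound 2, showing whether the carbamoyl link raises the number when the butyl chain stays in place.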